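The source may report more compounds than this note shows. Statements on the series, on what has been measured and on what is new or still open speak of the compounds shown alone.

Working notes on the amine series. Compound 1 `COC[C@H](NC1CCN(CCCc2c[nH]c3ccc(-n4cnnc4)cc23)CC1)c1ccccc1` gives 0.9 nM in an assay on CHO cells for agonist activity at 5-hydroxytryptamine receptor 1D (Homo sapiens), read by GTPgammaS binding; a lower number here means that less compound is needed, a higher number that more compound is needed for the effect. Going by the values given here, compound 2 `CC(=O)Nc1ccc(CNC2CCN(CCCc3c[nH]c4ccc(-n5cnnc5)cc34)CC2)cc1` gives 5 nM in this assay, which is a 5.6-fold higher number from compound 1 to compound 2 (0.74 log units; beyond the scatter); compound 2 therefore carries the higher of the two numbers so far, with compound 1 the only neighbour.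

Compound 3 `c1ccc(CNC2CCN(CCCc3c[nH]c4ccc(-n5cnnc5)cc34)CC2)cc1` is the next entry. Its change from compound 2 is hydrogen in place of acetamido on an aromatic carbon. Among the compounds with values here, the only measured step, a 5.6-fold higher number from compound 1 to compound 2 (0.74 log units; beyond the scatter), exchanged the whole substituent on the amine nitrogen and so bears only loosely on a removal of the acetamido alone; no step in the data isolates that group. On that footing the expectation is a step of a 1.2-fold higher number from compound 2 to compound 3 (0.08 log units; within the scatter) for compound 3, most likely within the scatter, with a higher number somewhat more probable than a lower one because compound 2 already sits at 5 nM. Compound 3 is thus estimated at 6 nM, with a range of 1.5 nM to 25 nM.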

Compound 3, half-maximal effective concentration: 7.6 nM
Compound 3: the middle estimate sits 1.3-fold (0.10 log units) below what was measured, within the range that was stated.
By their numbers in this assay, from the lowest: compound 1; then compounds 2 and 3 (each within the scatter of the next).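

In this assay, hydrogen in place of acetamido on the aromatic carbon gives a step within the scatter (a 1.5-fold higher number from compound 2 to compound 3 (0.18 log units; within the scatter)), so the benzyl amine does not depend measurably on the acetamido in this pair. Hydrogen in place of methoxymethyl on the saturated chain carbon bound to the amine nitrogen and the aromatic carbon gives a step beyond the scatter (an 8.4-fold higher number from compound 1 to compound 3 (0.93 log units; beyond the scatter)), which isolates the single change that separates compound 1 from compound 3. No measured evidence accounts for either step.

As far as these compounds go, it remains open whether a methyl group or a longer chain at that saturated carbon would give a number nearer that of compound 1 or that of compound 3. From the compounds shown here alone, it also remains open whether a carboxylic acid or an amine on the aromatic carbon would stay within the scatter of compound 3.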